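The source may hold more compounds than are shown below. What is called first, only, known or untested is meant among the compounds shown, and "the series" means these compounds.

Of the compounds shown here, three have numbers so far in a physicochemical assay for solubility, in phosphate buffer, at pH 7.4; a higher number here means a more soluble compound, a lower number a less soluble compound. Compound 1 (`OCC1CCN(c2nccnc2Oc2ccc(Nc3nc4ccccc4s3)cc2)CC1`) gives 6000 nM, compound 2 (`OCC1CCN(c2nccnc2OC2CN(c3cnc4ccccc4n3)C2)CC1`) gives 500000 nM and compound 3 (`OC1CCN(c2nccnc2OC2CN(c3ccc4ccccc4n3)C2)CC1`) gives 99000 nM. Compound 3 therefore stands second of the three, with a lower number than compound 2 and a higher number than compound 1, and both gaps lie beyond the scatter. For the measured compounds named here, these compounds differ from one another in more than one place, so no measured pair isolates a single change.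

Going by the values given here, compound 4 (`N#CC1CCN(c2nccnc2OC2CN(c3ccc4ccccc4n3)C2)CC1`) carries cyano in place of hydroxy on a saturated ring carbon, the only difference from compound 3: cyano in place of hydroxy on a saturated ring carbon. Among the compounds with values here, no measured step covers this exchange, so the expectation rests on the structural change alone and stays loose. A moderate move towards a lower number in this assay is expected, with the estimated step being a 2.5-fold lower number from compound 3 to compound 4 (0.39 log units; beyond the scatter). Compound 4 is estimated at 40000 nM, with an expected range of 12000 nM to 130000 nM.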

Compound 4, solubility: 66000 nM
The estimate for compound 4 lay 1.7-fold (0.22 log units) below the measured number, within the range that was stated.
By their numbers in this assay, from the lowest: compound 1; then compounds 4 and 3 (each within the scatter of the next); then compound 2.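

In this assay, for the compounds shown here, the exchange of 4-hydroxypiperidin-1-yl for 4-cyanopiperidin-1-yl gives a 1.5-fold lower number from compound 3 to compound 4 (0.18 log units; within the scatter), the first comparison that isolates a single place. Hydroxy brings a hydrogen-bond donor and cyano brings none, yet this pair is not separated beyond the usual scatter, so the read-out does not distinguish the two groups at this ring carbon. This holds for one pair on one core only, and no explanation of the result is available from other measurements.

On these data alone, whether an amine or a carboxylic acid on the same saturated ring carbon would also stay within the scatter of compound 3 remains open. Also open, as far as these compounds go, is whether the same exchange would read alike on the core of compound 1 or on the core of compound 2.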